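Swapping an isopropoxyphenyl for a difluorophenyl in a legumain inhibitor

The compounds below may be only part of what the source reports. "The series", "measured", "known", "first", "only" and "open" are said of these compounds alone.

Of the compounds shown here, three have been tested in an assay on isolated protein for inhibition of legumain (Homo sapiens), with stated times of 2 min and 60 min; a lower number here means a stronger inhibitor, a higher number a weaker inhibitor. Compound 1 `C[C@@H](C(=O)N[C@H](C#N)CC(N)=O)N(Cc1ccc(-c2cccc(C(F)(F)F)c2)cc1)S(C)(=O)=O` gives 601 nM, compound 3 `CC(C(=O)N[C@H](C#N)CC(N)=O)N(Cc1ccc(-c2cccc(Cl)c2)cc1)S(C)(=O)=O` gives 425 nM, and compound 2 `CC(C)Oc1cccc(-c2ccc(CN([C@H](C)C(=O)N[C@H](C#N)CC(N)=O)S(C)(=O)=O)cc2)c1` gives 5050 nM, the highest number of the three and beyond the scatter from both of the others. The untested compound 4 `C[C@H](C(=O)N[C@H](C#N)CC(N)=O)N(Cc1ccc(-c2ccc(F)c(F)c2)cc1)S(C)(=O)=O` differs from compound 2 in one place, on an aromatic carbon of a six-membered aromatic ring of carbon only, para to a large group: 3,4-difluorophenyl in place of 3-isopropoxyphenyl on an aromatic carbon. With compounds 1 and 3, both carrying small substituents on that ring, giving lower numbers than compound 2, compound 4 is expected to move downward in this assay, with an estimated step of a 6.3-fold lower number from compound 2 to compound 4 (0.80 log units; beyond the scatter). The estimate for compound 4 is 800 nM, ranging from 300 nM to 2500 nM.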

Compound 4, half-maximal inhibitory concentration: 6300 nM
The estimate for compound 4 lay 7.9-fold (0.90 log units) below the measured number; the measured number lies above the stated range.
By their numbers in this assay, from the lowest: compounds 3 and 1 (each within the scatter of the next); then compounds 2 and 4 (each within the scatter of the next).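

In this assay, putting 3,4-difluorophenyl in place of 3-isopropoxyphenyl gives a 1.2-fold higher number from compound 2 to compound 4 (0.10 log units; within the scatter). At this aromatic carbon, then, removing the isopropoxy group and its hydrogen-bond acceptor, with fluorine atoms taking its place, leaves the number unchanged within the usual scatter. No available evidence bears on what lies behind this result.

Still open, on these data alone, is how a ring carrying an aminomethyl group or a carboxylic acid would read in this assay. A single fluorine on this ring also remains to be compared with the 3,4-difluorophenyl group.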